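Methylsulfonyl in place of methylsulfanyl on a shared core

The source may hold more compounds than are shown below. What is called first, only, known or untested is meant among the compounds shown, and "the series" means these compounds.

Measured so far in a functional assay for agonist activity at Alpha-1D adrenergic receptor (Homo sapiens); a higher number here means that more compound is needed for the effect, a lower number that less compound is needed:
compound 1 `CSc1c(F)cccc1NCC1=NCCN1` gives 33.9 nM.
compound 3 `CSc1ccc(Cl)cc1NCC1=NCCN1` gives 2.69 nM.
compound 2 `CS(=O)(=O)c1ccc(Cl)cc1NCC1=NCCN1` gives only a limit of the assay, < 100000 nM.

Compound 1 stands higher than compound 3; the difference between the two cores is not broken down here. The change from compound 3 to compound 2 is methylsulfonyl in place of methylsulfanyl on an aromatic carbon, and its size in this assay, a step that the limit leaves unreadable from compound 3 to compound 2, cannot be read because of the limit of < 100000 nM in this assay, at which 1 of the 3 values shown sits. Compound 4 `CS(=O)(=O)c1c(F)cccc1NCC1=NCCN1` is not yet measured. It differs from compound 1 by methylsulfonyl in place of methylsulfanyl on an aromatic carbon, the same kind of change, although here the place is ortho to a fluoro group, whereas in compound 2 it is para to a chloro group. Since compound 2 reached only a limit < 100000 nM, compound 4 is expected to give a large step, a 1200-fold higher number from compound 1 to compound 4 (3.07 log units; beyond the scatter). The estimate for compound 4 is 40000 nM, within 2000 nM to 200000 nM.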

Compound 4, half-maximal effective concentration: < 100000 nM
Compound 4: no number, only a limit; the forecaster's own chance of this, stated with the estimate: 65%; the middle value does not contradict the limit.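

The step from compound 1 to compound 4 cannot be read, because compound 4 gives no number, only a limit: the limit of < 100000 nM in this assay, at which 2 of the 4 values shown sit.

The compounds shown leave open how large the methylsulfonyl change really is in this assay, and whether it differs in size between compound 2 and compound 4.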